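The source may report more compounds than this note shows. Statements on the series, on what has been measured and on what is new or still open speak of the compounds shown alone.

Measured in a physicochemical assay for lipophilicity, read by HPLC, at pH 7.5; on this read-out lower numbers stand for lower lipophilicity and higher numbers for higher lipophilicity:
- compound 1 `CC[C@@H](Nc1c(C#N)c(-c2ccc(-c3cccc(C)c3)cc2)nc2cnccc12)C(N)=O`: 3
- compound 2 `CC[C@@H](Nc1c(C#N)c(-c2ccc(-c3cccc(Cl)c3OC)cc2)nc2cnccc12)C(N)=O`: 3.1
- compound 3 `CC[C@@H](Nc1c(C#N)c(-c2ccc(-c3ccccc3N(C)C)cc2)nc2cnccc12)C(N)=O`: 3.2

Compound 3 cannot be separated from the other two on these numbers: the steps read a number 0.20 log units higher from compound 1 to compound 3 (within the scatter) and a number 0.10 log units higher from compound 2 to compound 3 (within the scatter).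

The next structure is compound 4 `CC[C@@H](Nc1c(C#N)c(-c2ccc(-c3ccccc3C)cc2)nc2cnccc12)C(N)=O`, with methyl in place of dimethylamino on an aromatic carbon. Among the compounds with values here, three measured steps bear on this change, since each swaps the same aryl group: a number 0.10 log units higher from compound 1 to compound 2 (within the scatter), together with the two above. Within the data shown here, none leaves the scatter, and no measured pair isolates 2-methylphenyl itself. No step beyond the scatter is therefore expected in this assay. The expected change is a number 0.10 log units lower from compound 3 to compound 4 (within the scatter). For compound 4 the estimate is 3.1, with an expected range of 2.8 to 3.4.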

Compound 4, distribution coefficient: 3
Compound 4: the middle estimate sits 0.10 log units above what was measured; measured number inside the range.
By their numbers in this assay, from the lowest: compounds 1, 4, 2 and 3 (each within the scatter of the next).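

In this assay, within the data shown here, the change at this position gives a number 0.20 log units lower from compound 3 to compound 4 (within the scatter) and thus isolates methyl against dimethylamino for the first time, without leaving the scatter. The other two new comparisons give a number 0.10 log units lower from compound 2 to compound 4 (within the scatter) and no change at the digits printed from compound 1 to compound 4 (within the scatter), so 2-methylphenyl cannot be separated from 3-methylphenyl or 3-chloro-2-methoxyphenyl, and all four aryl groups remain indistinguishable on this read-out. No supporting data bear on why these readings fall so close together.

All four compounds carry uncharged aryl substituents. From the compounds shown here alone, whether a carboxylic acid or a primary amine on this aromatic ring would produce a step beyond the scatter remains open.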